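Methoxybenzyl to methyl on the shared core

The source may report more compounds than this note shows. Statements on the series, on what has been measured and on what is new or still open speak of the compounds shown alone.

Among the compounds with values here, compound 1 `COc1ccc(Cn2cc3cc(C(=N)Nc4ccc(N5CCN(C)CC5)cc4)ncc3n2)cc1` is one of two compounds measured in a functional assay on MDA-MB-231 cells (Homo sapiens) for cytotoxicity, read by MTT assay, with a stated time of 72 h; a higher number here means a weaker inhibitor, a lower number a stronger inhibitor; compound 1 gives 8000 nM. Compound 2 `N=C(Nc1cccc(C(F)(F)F)c1)c1cc2c(-c3ccccc3)n[nH]c2cn1` is the other one measured in this assay, and compound 2 gives 22300 nM. On these two numbers compound 1 has the lower value, and the gap to compound 2 is beyond the scatter; the two structures differ in several places at once, so the gap cannot be read as a single step.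

Compound 3 `CN1CCN(c2ccc(NC(=N)c3cc4cn(C)nc4cn3)cc2)CC1` is not yet measured in this assay. Against compound 1 it carries hydrogen in place of 4-methoxyphenyl on a saturated chain carbon bound to an aromatic nitrogen; cut one bond further out, the same change reads as 4-methoxybenzyl to methyl. Within the data shown here, no measured pair in the set shows this change on its own, so the size of the step is open. What leaves is a whole aromatic ring with its methoxy group, and the expectation is a step toward a higher number, of modest size, possibly no more than the scatter. Compound 3 is estimated at 12000 nM, with a range of 5000 nM to 30000 nM, which means an expected step of a 1.5-fold higher number from compound 1 to compound 3 (0.18 log units; within the scatter).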

Compound 3, half-maximal inhibitory concentration: 20500 nM
Compound 3: middle estimate off by 1.7-fold (0.23 log units), on the low side; the measured number falls inside the stated range.
By their numbers in this assay, from the lowest: compound 1; then compounds 3 and 2 (each within the scatter of the next).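

Within the data shown here, the first single-place comparison now exists: in this assay, replacing 4-methoxybenzyl with methyl on the shared core gives a 2.6-fold higher number from compound 1 to compound 3 (0.41 log units; beyond the scatter). This shows that the value responds to the group at this position, and that the 4-methoxyphenyl group on a saturated chain carbon bound to an aromatic nitrogen is not needed for a measurable value, as compound 3 still gives 20500 nM. No measurement in hand accounts for the size or direction of this step.

The compounds shown give only the two ends of this change, so it remains open whether the step follows the aromatic ring as a whole or its methoxy group, a question that a plain benzyl group or a cyclohexylmethyl group at this position would address. Also open, on these data alone, is how the value behaves across intermediate groups at this position, such as an ethyl group or a longer chain such as n-butyl, and whether a 4-hydroxybenzyl group would track with the 4-methoxybenzyl group of compound 1.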